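Methoxy for fluoro on two related cores

The compounds below may be only part of what the source reports. "The series", "measured", "known", "first", "only" and "open" are said of these compounds alone.

Measured in a functional assay on A549 cells (Homo sapiens) for cytotoxicity, read by MTT assay, with a stated time of 48 h; a higher number here means a weaker inhibitor, a lower number a stronger inhibitor:
compound 1 `Cc1ccc(Cn2c(/C=C3\SC(=S)N(CC(=O)O)C3=O)nc3cc(F)ccc32)cc1` gives 13800 nM
compound 2 `Cc1ccc(Cn2c(/C=C3\SC(=S)N(CC(=O)O)C3=O)nc3ccc(F)cc32)cc1` gives 9640 nM
compound 3 `COc1ccc2c(c1)nc(/C=C1\SC(=S)N(CC(=O)O)C1=O)n2Cc1ccc(C)cc1` gives 5680 nM

Compound 1 and compound 2 are built from the same atoms joined differently; the difference between the two cores is not broken down here. Their two values lie within the scatter of each other, and the same holds for compound 2 against compound 3. Compound 3 differs from compound 1 by a single change, (methoxy in place of fluoro on an aromatic carbon), and that change gave a 2.4-fold lower number from compound 1 to compound 3 (0.39 log units; beyond the scatter).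

Compound 4 `COc1ccc2nc(/C=C3\SC(=S)N(CC(=O)O)C3=O)n(Cc3ccc(C)cc3)c2c1` is not yet measured. It differs from compound 2 by methoxy in place of fluoro on an aromatic carbon, the same change, at a place described in exactly the same words as for compound 3. Going by the values given here, only one measured pair carries this change, so the expectation rests on that pair alone, where a 2.4-fold lower number from compound 1 to compound 3 (0.39 log units; beyond the scatter). The expected step from compound 2 to compound 4 in this assay is a 2.2-fold lower number from compound 2 to compound 4 (0.35 log units; beyond the scatter), set beside the earlier step, with wider uncertainty since a single pair cannot show how the change behaves on the second core. For compound 4 the estimate is 4300 nM, expected to fall between 2200 nM and 9000 nM.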

Compound 4, half-maximal inhibitory concentration: 23600 nM
For compound 4 the middle estimate is 5.5-fold (0.74 log units) below the measured one; the measured number lies above the stated range.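

In this assay, methoxy in place of fluoro on the core of compound 2 gave a 2.4-fold higher number from compound 2 to compound 4 (0.39 log units; beyond the scatter). The same change therefore runs in opposite directions on the two cores: the same change on two cores in this assay, a 2.4-fold lower number (0.39 log units; beyond the scatter) from compound 1 to compound 3 and a 2.4-fold higher number (0.39 log units; beyond the scatter) from compound 2 to compound 4, 5.9-fold (0.77 log units) apart, beyond the scatter of two such steps. For this series, the direction of the step on one core did not carry over to the other; the notes show that the two cores can part ways on this change, but with one pair per core they do not show the reason, nor how the change would behave on any further core.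

The compounds shown leave open whether this reversal is particular to methoxy, or whether a hydroxyl, a chloro or an amine in the same two places would also split between the cores. Also open, on these data alone, is whether the split survives a change elsewhere in the molecule, such as a methyl ester in place of the carboxylic acid.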